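Methoxy in place of methyl, carried to a second core

This account rests on a few compounds, and the source may have more. Where it says the series, first, only, none or still open, it means among the compounds named here.

Compound 1 `CCC(C1CC1)n1nc(C)nc(Nc2c(Cl)cc(C(F)(F)F)cc2Cl)c1=O` and compound 2 `COCC(C1CC1)n1nc(C)nc(Nc2c(Cl)cc(C(F)(F)F)cc2Cl)c1=O` share one core and differ by methoxy in place of methyl on a saturated chain carbon, two bonds along the chain from an aromatic nitrogen and a saturated ring carbon. In an assay on isolated protein for displacement of a labelled ligand from corticotropin-releasing factor receptor 1 (Rattus norvegicus) (a lower number here means a stronger inhibitor, a higher number a weaker inhibitor), compound 1 gives 6.3 nM. In the same assay compound 2 gives 11 nM. The step is a 1.7-fold higher number from compound 1 to compound 2 (0.24 log units; within the scatter), so the methoxy leaves the half-maximal inhibitory concentration essentially where it was.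

Compound 3 `CCC(C1CC1)n1nc(C)nc(Nc2ccc(OC)nc2C(F)(F)F)c1=O` carries a different core; the difference between the two cores is not broken down here. In this assay compound 3 gives 3.7 nM, a number that sits within the scatter of compound 1 and beyond the scatter from compound 2.

Compound 4 `COCC(C1CC1)n1nc(C)nc(Nc2ccc(OC)nc2C(F)(F)F)c1=O` is not yet measured. Within the data shown here, it differs from compound 3 by methoxy in place of methyl on a saturated chain carbon, two bonds along the chain from an aromatic nitrogen and a saturated ring carbon, the same change as the one between compound 1 and compound 2, at a place described in the same words. For compound 4 the expected step is a 1.6-fold higher number from compound 3 to compound 4 (0.21 log units; within the scatter), resting on the earlier 1.7-fold higher number from compound 1 to compound 2 (0.24 log units; within the scatter) in the first core. Compound 4 is therefore estimated at 6 nM in this assay, with a range from 3 nM to 13 nM.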

Compound 4, half-maximal inhibitory concentration: 3.7 nM
Beside the measured number, compound 4's estimate is 1.6-fold (0.21 log units) above it, within the range that was stated.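

On the core of compound 3, the change of 1-cyclopropylpropyl to 1-cyclopropyl-2-methoxyethyl gives, in this assay, no change at the digits printed from compound 3 to compound 4 (within the scatter). Read side by side, the two cores show no difference in how they take this change: the same change on two cores in this assay, a 1.7-fold higher number (0.24 log units; within the scatter) from compound 1 to compound 2 and no change at the digits printed (within the scatter) from compound 3 to compound 4, 1.7-fold (0.24 log units) apart, within the scatter of two such steps

Methoxy in place of methyl at this saturated chain carbon is therefore tolerated on both cores, and the step read on the core of compound 1 carried over to the core of compound 3 without a gap that stands out, but with both steps inside the scatter, this is agreement between two small steps and says nothing about what the methoxy itself contributes, nor does a pair of cores amount to a rule for the series.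

The compounds shown leave open whether a hydroxyl, an amine or a longer alkoxy chain at this same saturated chain carbon would also keep the number within the scatter. They also leave open whether the same holds on any third core, or in any read-out other than this assay.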